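A New Group on the Carbonyl of Compound 2

The source may hold more compounds than are shown below. What is called first, only, known or untested is meant among the compounds shown, and "the series" means these compounds.

In a functional assay on HEp-2 cells (Homo sapiens) for cytotoxicity, with a stated time of 24 h (a lower number here means a stronger inhibitor, a higher number a weaker inhibitor), compound 1 `Cc1ccc(NC(=O)c2c(-c3ccccc3)c(-c3ccccc3)nn2-c2ccccc2)cc1` gives 1.21 ug/mL and compound 2 `Cc1ccc(NC(=O)c2c(-c3ccc(Cl)cc3)c(-c3ccccc3)nn2-c2ccccc2)cc1` gives 0.81 ug/mL. Within the data shown here, the one measured step, chloro in place of hydrogen on an aromatic carbon, is a 1.5-fold lower number from compound 1 to compound 2 (0.17 log units; within the scatter), so these two compounds cannot be ranked and compound 2 stands level with its only neighbour.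

Compound 3 `O=C(c1c(-c2ccc(Cl)cc2)c(-c2ccccc2)nn1-c1ccccc1)n1c(=S)[nH]c2ccccc21` keeps the core of compound 2, chloro included, and differs from it on the carbonyl carbon: a group of 10 heavy atoms (7 carbon, 2 nitrogen, 1 sulfur; one five-membered aromatic ring with 2 hetero atoms, one six-membered aromatic ring of carbon only) in place of a group of 8 heavy atoms (7 carbon, 1 nitrogen; one six-membered aromatic ring of carbon only), on a carbonyl carbon. The (4-methylphenyl)amino group leaves, and the group that enters carries one five-membered aromatic ring with 2 hetero atoms and one six-membered aromatic ring of carbon only.

Among the measured compounds shown here, no measured step touches this place, so the chloro step gives neither a size nor a direction for the new change. The estimate therefore starts from compound 2 at 0.81 ug/mL, with no shift beyond the scatter expected, though the uncertainty is wide. The expected change is a 1.2-fold higher number from compound 2 to compound 3 (0.09 log units; within the scatter). For compound 3 the estimated value is 1 ug/mL, with an expected range from 0.3 ug/mL to 4 ug/mL.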

Compound 3, half-maximal inhibitory concentration: 1.54 ug/mL
Estimate against measurement, compound 3: 1.5-fold (0.19 log units) below; measured number inside the range.
By their numbers in this assay, from the lowest: compounds 2, 1 and 3 (each within the scatter of the next).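

In this assay, the first exchange on the carbonyl carbon gives a 1.9-fold higher number from compound 2 to compound 3 (0.28 log units; within the scatter), so this place, unlike the aromatic carbon of the chloro step, is now shown to accept a change of a whole group without a reading beyond the scatter. The (4-methylphenyl)amino group is therefore not needed to hold a number at this level, at least when the entering group carries one five-membered aromatic ring with 2 hetero atoms, one six-membered aromatic ring of carbon only, and a sulfur. The exchange alters the ring set, the heavy atoms and the hydrogen-bond acceptor count together, so the result cannot be assigned to any one of these, and no measurement available here accounts for it.

On these data alone, it remains open whether this tolerance extends to much smaller or open-chain groups on the carbonyl carbon, such as a hydroxyl, which would give the carboxylic acid, or diethylamino. Also unresolved is what the sulfur contributes, which a version of the entering group with oxygen in its place would test.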